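Amide Nitrogen Substituents and Paw Edema Inhibition

The source may hold more compounds than are shown below. What is called first, only, known or untested is meant among the compounds shown, and "the series" means these compounds.

Compound 1 `O=C(NCc1ccccc1)c1c(O)c2cccnc2n(-c2ccccc2)c1=O`: 11.3%
Compound 2 `CN(C)CCNC(=O)c1c(O)c2cccnc2n(-c2ccccc2)c1=O`: 18.4%
Compound 3 `O=C(Nc1ccc(Cl)cc1)c1c(O)c2cccnc2n(-c2ccccc2)c1=O`: 2.5%

In a functional assay on the whole organism for inhibition, with Rattus norvegicus as the target, read by cytopathic effect and paw edema, at a dose of 100 mg/kg by the oral route (a lower number here means less inhibition, a higher number more inhibition at the dose given (going by the name of the read-out)), compound 1 stands second highest of the three numbers. Its nearest neighbour is compound 2, reached by a number 7.1 percentage points higher from compound 1 to compound 2 (within the scatter). Its furthest is compound 3, reached by a number 8.8 percentage points lower from compound 1 to compound 3 (within the scatter).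

Compound 4 `COc1cccc(NC(=O)c2c(O)c3cccnc3n(-c3ccccc3)c2=O)c1` has not been measured. It differs from compound 1 in one place: 3-methoxyphenyl in place of benzyl on an amide-type nitrogen. The step that bears most on this is the one in which 4-chlorophenyl took the place of benzyl on the amide-type nitrogen, a number 8.8 percentage points lower from compound 1 to compound 3 (within the scatter), a change within the scatter. A ring attached directly to that nitrogen is therefore expected to give a number somewhat lower, but no step beyond the scatter is expected: a number 4.3 percentage points lower from compound 1 to compound 4 (within the scatter).

Compound 4 is estimated at 7%, within a range from 0% to 18%.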

Compound 4, a percentage reported as inhibition, in the whole organism at one dose (the size of the read-out at that dose, not a potency): 20.7%
Beside the measured number, compound 4's estimate is 13.7 percentage points below it; measured number above the stated range.
By their numbers in this assay, from the lowest: compounds 3, 1, 2 and 4 (each within the scatter of the next, the first and the last beyond it).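

A ring attached directly to the amide-type nitrogen does not by itself bring the number down: 3-methoxyphenyl in place of 4-chlorophenyl gives a number 18.2 percentage points higher from compound 3 to compound 4 (beyond the scatter). What the ring carries, or where, therefore counts, while a number 9.4 percentage points higher from compound 1 to compound 4 (within the scatter) and a number 2.3 percentage points higher from compound 2 to compound 4 (within the scatter) leave compound 4 not separated from the benzyl and 2-(dimethylamino)ethyl amides. Nothing shown here explains the difference between the two rings.

Compound 3 and compound 4 differ in both the group on the ring and where it sits, so these two remain tangled. A 3-chlorophenyl or 4-methoxyphenyl on this nitrogen would separate them, and plain phenyl remains an open comparison.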